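Trimming the ethoxy group of compound 3

The source may report more compounds than this note shows. Statements on the series, on what has been measured and on what is new or still open speak of the compounds shown alone.

Measured in a functional assay on SW-620 cells (Homo sapiens) for cytotoxicity; on this read-out lower numbers stand for stronger inhibition and higher numbers for weaker inhibition:
compound 1 `COc1ccc2nc(NC(=O)CCCCC(=O)NO)sc2c1`: 9.07 ug/mL
compound 2 `O=C(CCCCCCC(=O)Nc1nc2ccccc2s1)NO`: 4.01 ug/mL
compound 3 `CCOc1ccc2nc(NC(=O)CCCCCCC(=O)NO)sc2c1`: 10.4 ug/mL

Compound 3 stands within the scatter of compound 1, and compound 2 lies clearly lower than both. Compound 4 `COc1ccc2nc(NC(=O)CCCCCCC(=O)NO)sc2c1` differs from compound 3 in one place: hydrogen in place of methyl on a saturated chain carbon bound to an oxygen on an aromatic ring, so ethoxy becomes methoxy. For the measured compounds named here, the one measured step that bears on this is modest, a 2.6-fold higher number from compound 2 to compound 3 (0.41 log units; beyond the scatter), with ethoxy in place of hydrogen on an aromatic carbon. Removing only the methyl is a smaller change, so no step beyond the scatter is expected in this assay, with a slight lean towards lower numbers. The expected step is a 1.3-fold lower number from compound 3 to compound 4 (0.11 log units; within the scatter). Compound 4 is estimated at 8 ug/mL, with an expected range of 4.5 ug/mL to 14 ug/mL.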

Compound 4, half-maximal inhibitory concentration: 0.96 ug/mL
Estimate against measurement, compound 4: 8.3-fold (0.92 log units) above; the measured number lies below the stated range.
By their numbers in this assay, from the lowest: compound 4; then compound 2; then compounds 1 and 3 (each within the scatter of the next).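

In this assay, a single methyl on the saturated chain carbon bound to the aromatic oxygen carries a large effect, with an 11-fold lower number from compound 3 to compound 4 (1.03 log units; beyond the scatter). The direction of change from hydrogen depends on that methyl: methoxy gives a 4.2-fold lower number from compound 2 to compound 4 (0.62 log units; beyond the scatter), whereas ethoxy gives a 2.6-fold higher number from compound 2 to compound 3 (0.41 log units; beyond the scatter). With methoxy held constant, the chain difference also counts, with a 9.4-fold lower number from compound 1 to compound 4 (0.98 log units; beyond the scatter). Nothing available explains why the methyl matters so much. Where a hydroxy or propoxy group at this aromatic carbon would fall remains open.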